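Switching the Aryl Group on the Ring Nitrogen

The compounds below may be only part of what the source reports. "The series", "measured", "known", "first", "only" and "open" are said of these compounds alone.

Compound 1, `O=C(NCCCCc1ccccc1)c1cccc(C2SCC(=O)N2c2ccccc2F)c1`: 83%
Compound 2, `COc1c(F)cccc1N1C(=O)CSC1c1cccc(C(=O)NCCCCc2ccccc2)c1`: 9%

Two compounds share one core and differ only in the aryl group on the amide-type nitrogen in the ring. In a functional assay on HOS cells (Homo sapiens) for inhibition, read by CCK-8 assay, with a stated time of 72 h, tested at 1 uM (a lower number here means less inhibition, a higher number more inhibition at the concentration tested (going by the name of the read-out)), compound 1 gives 83%, while compound 2 gives 9%. Among the measured compounds shown here, the single measured step, a number 74 percentage points lower from compound 1 to compound 2 (beyond the scatter), is the only guide available. For the measured compounds named here, compound 2 thus stands lowest of the two numbers, with compound 1 as its only neighbour, far above it.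

Compound 3, `COc1ccc(N2C(=O)CSC2c2cccc(C(=O)NCCCCc3ccccc3)c2)c(OC)c1`, is not yet measured. (2,4-dimethoxyphenyl in place of 3-fluoro-2-methoxyphenyl on an amide-type nitrogen in a ring). Going by the values given here, no measured step covers this exchange itself; the one step that exists, from compound 1 to compound 2, bears on it only in showing that replacing the aryl group on this nitrogen can shift this assay a great deal, in that case downward. Since compound 2 sits close to the floor, the estimated step of a number 16 percentage points higher from compound 2 to compound 3 (beyond the scatter) points upward, but its size is uncertain. Compound 3 is therefore expected to give 25%, with a range from 3% to 65%.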

Compound 3, a percentage reported as inhibition, at one concentration (the size of the read-out at that concentration, not a potency): 82%
Compound 3: the middle estimate sits 57 percentage points below what was measured; the whole stated range lies below it.
By their numbers in this assay, from the lowest: compound 2; then compounds 3 and 1 (each within the scatter of the next).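

In this assay, putting 2,4-dimethoxyphenyl in place of 3-fluoro-2-methoxyphenyl on the amide-type nitrogen gives a number 73 percentage points higher from compound 2 to compound 3 (beyond the scatter) and so restores the level of the 2-fluorophenyl compound, which shows that the earlier drop does not hold for every change of the aryl group at this position. The step of a number 1 percentage points lower from compound 1 to compound 3 (within the scatter) places 2-fluorophenyl and 2,4-dimethoxyphenyl on a par here, even though the two groups differ in their substituents, and since the names of the groups in compound 2 and compound 3 both include a methoxy group at the 2 position, that methoxy group alone does not go with the low reading of compound 2. Nothing available explains why compound 2 alone reads so low.

The three compounds leave open whether the low reading of compound 2 depends on the fluorine at the 3 position of its aryl group or on the pairing of that fluorine with the methoxy group. They also leave open how this assay would read with a plain phenyl, a dimethylamino group or a carboxylic acid on that aryl ring, or with a shorter chain in place of the 4-phenylbutyl amide side chain.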